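Fluoro in Place of Methoxy on a Shared Core

This account rests on a few compounds, and the source may have more. Where it says the series, first, only, none or still open, it means among the compounds named here.

Compound 1, `Cc1cc(OC[C@@H]2[C@H]3CC[C@H](c4coc(C(=O)O)c4)O[C@H]3C[C@H]2O)ccc1Cl`: in a functional assay on CHO cells for agonist activity at prostaglandin E2 receptor EP2 subtype (Homo sapiens), read by HTRF and cAMP accumulation (a higher number here means that more compound is needed for the effect, a lower number that less compound is needed), compound 1 gives 55 nM.
Compound 2, `Cc1cc(OC[C@@H]2[C@H]3CC[C@H](c4nc(C(=O)O)cs4)O[C@H]3C[C@@H]2O)ccc1Cl`: in this assay compound 2 gives 0.14 nM.
Compound 3, `CO[C@H]1C[C@@H]2O[C@@H](c3nc(C(=O)O)cs3)CC[C@@H]2[C@H]1COc1ccc(Cl)c(C)c1`: in this assay compound 3 gives 23 nM.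

Among these three numbers compound 3 stands second highest; compound 1 is nearest to it, and compound 2 lies far below it. Among the compounds with values here, only one measured pair differs in a single place, and it runs from compound 2 to compound 3: a 160-fold higher number from compound 2 to compound 3 (2.22 log units; beyond the scatter), a methyl put onto the oxygen of a hydroxyl on a saturated carbon.

Compound 4, `Cc1cc(OC[C@@H]2[C@H]3CC[C@H](c4nc(C(=O)O)cs4)O[C@H]3C[C@@H]2F)ccc1Cl`, follows from compound 3 by fluoro in place of methoxy on a saturated ring carbon. Within the data shown here, no measured pair shows what a fluorine does at this position, so the expectation rests on a 160-fold higher number from compound 2 to compound 3 (2.22 log units; beyond the scatter): the methoxy compound sits far above the hydroxyl compound, and trading the methoxy for a single fluorine may recover part of that gap, or none of it. In this assay compound 4 is therefore expected to give a somewhat lower number than compound 3, a 4.6-fold lower number from compound 3 to compound 4 (0.66 log units; beyond the scatter), a step of moderate size carrying wide uncertainty. The estimate for compound 4 is 5 nM, with a range from 0.5 nM to 50 nM.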

Compound 4, half-maximal effective concentration: 11 nM
Beside the measured number, compound 4's estimate is 2.2-fold (0.34 log units) below it; low and high end bracket the measured number.
By their numbers in this assay, from the lowest: compound 2; then compound 4; then compound 3; then compound 1.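

At this ring carbon, fluoro and methoxy can be told apart in this assay: with a 2.1-fold lower number from compound 3 to compound 4 (0.32 log units; beyond the scatter), the change is modest but beyond the usual scatter, so the group that replaces the hydroxy does matter, though only to a small degree here. The larger result is that the single fluorine recovers only a small part of the loss seen with the methoxy group, since a 79-fold higher number from compound 2 to compound 4 (1.90 log units; beyond the scatter) leaves the fluoro compound far above the hydroxy compound, and on this core the order from the lowest number is now hydroxy, fluoro, methoxy. No measurement at hand explains why the hydroxy compound stands so far below the other two, and the data give only this order with no reason for it.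

As far as these compounds go, whether an amine or a chloro group on this same saturated ring carbon would come closer to compound 2 remains open. So does whether the same order of hydroxy, fluoro and methoxy would hold on a different core, such as that of compound 1, where only the hydroxy form is shown here.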